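Swapping a lactam for a dimethylpyrazole on a fused core

This account rests on a few compounds, and the source may have more. Where it says the series, first, only, none or still open, it means among the compounds named here.

Of the compounds shown here, three have been measured in a physicochemical assay for solubility, read by LC-MS, in phosphate buffer, with a stated time of 24 h, at pH 7.4; a higher number here means a more soluble compound, a lower number a less soluble compound. Compound 1 `O=C1CCCN1c1cnc(NCc2c(F)ccc3c2CCO3)c2cn[nH]c(=O)c12` gives only a limit there, < 2000 nM; this is a limit of the assay rather than a number, noted as the limit of < 2000 nM in this assay, at which 1 of the 3 values shown sits. Compound 2 `O=C(Nc1cnc(NCc2c(F)ccc3c2CCO3)n2cnnc12)c1cccnc1` gives 12000 nM in this assay, and compound 3 `O=C1CCCN1c1cnc(NCc2c(F)ccc3c2CCO3)n2cnnc12` gives 640000 nM. Going by the values given here, the one step between compounds differing in a single place is a 53-fold higher number from compound 2 to compound 3 (1.73 log units; beyond the scatter), a large gain on a core different from that of compound 1.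

Compound 4 `Cc1nn(C)cc1-c1cnc(NCc2c(F)ccc3c2CCO3)c2cn[nH]c(=O)c12` shares the core of compound 1 and differs from it at one position: 1,3-dimethyl-1H-pyrazol-4-yl in place of 2-oxopyrrolidin-1-yl on an aromatic carbon. Among the compounds with values here, no measured step touches this change. The step from compound 2 to compound 3 concerns another core and another pair of groups, so it carries little over to compound 4, and the starting point for compound 1 is itself only a limit. Within the data shown here, with no measured precedent, the expectation is that compound 4 stays near where compound 1 sits, and the expected step is a step that the limit leaves unreadable from compound 1 to compound 4. Compound 4 is thus estimated at 1500 nM in this assay, expected to lie between 300 nM and 10000 nM, with a fair chance that only a limit is reported.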

Compound 4, solubility: 9000 nM
Beside the measured number, compound 4's estimate is 6.0-fold (0.78 log units) below it; low and high end bracket the measured number.
By their numbers in this assay, from the lowest: compounds 4 and 2 (each within the scatter of the next); then compound 3. At a limit, below all of these: compound 1.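

In this assay, going by these compounds alone, the move to 1,3-dimethyl-1H-pyrazol-4-yl in place of 2-oxopyrrolidin-1-yl, on an aromatic carbon of the shared core, gives an at least 4.5-fold higher number from compound 1 to compound 4 (0.65 log units; beyond the scatter), and so provides the first readable number on this core. Compound 1 gives a limit and not a number, so the step has a floor but no known full size: the limit of < 2000 nM in this assay, at which 1 of the 4 values shown sits. The one earlier step, a 53-fold higher number from compound 2 to compound 3 (1.73 log units; beyond the scatter), has 2-oxopyrrolidin-1-yl as the entering group on another core and against another partner, whereas here that group leaves and the number still rises, so among the compounds shown it does not go with the higher number in every setting.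

What the compounds shown leave open is which part of the new group carries the step: the aromatic ring itself, or one or both of its methyl groups, as a pyrazole with no methyl groups would test. Also open, going by these compounds, is whether 1,3-dimethyl-1H-pyrazol-4-yl would act the same way on the core of compound 3, and how a basic amine such as a piperazine or a carboxylic acid would read at this position.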